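The compounds below may be only part of what the source reports. "The series", "measured", "known", "first", "only" and "open" are said of these compounds alone.

Measured compounds:
Compound 1, `COc1ccc(CN(C(C)=O)c2cc(OC)c(OC)c(OC)c2)cc1O`: 270 nM
Compound 2, `COc1ccc(N(Cc2cc(OC)c(OC)c(OC)c2)C(=O)CCl)cc1O`: 22500 nM
Compound 3, `COc1ccc(CNc2cc(OC)c(OC)c(OC)c2)cc1F`: 32200 nM

These values come from a functional assay on HCT-116 cells (Homo sapiens) for inhibition, read by MTT assay, with a stated time of 48 h; on this read-out lower numbers stand for stronger inhibition and higher numbers for weaker inhibition. Of the three, compound 1 gives the lowest number, and compound 2 and compound 3 both lie far beyond the scatter above it, so compound 1 is the most potent of the measured set. The unmeasured compound 4, `C=CC(=O)N(Cc1ccc(OC)c(O)c1)c1cc(OC)c(OC)c(OC)c1`, keeps the core of compound 1 and differs in one place: vinyl in place of methyl on a carbonyl carbon. The carbonyl carbon that carries the vinyl group is still attached to the amide-type nitrogen. Among the compounds with values here, no measured pair shows this exact change, and compound 2 and compound 3 differ from compound 1 in other ways, so they give no direct guide to its size. In this assay a small step is expected, within or just beyond the scatter: a 1.4-fold lower number from compound 1 to compound 4 (0.13 log units; within the scatter). Compound 4 is estimated at 200 nM, with a range from 50 nM to 800 nM.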

Compound 4, half-maximal inhibitory concentration: 98 nM
Compound 4: the middle estimate sits 2.0-fold (0.31 log units) above what was measured; measured number inside the range.
By their numbers in this assay, from the lowest: compound 4; then compound 1; then compounds 2 and 3 (each within the scatter of the next).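

In this assay the change reads a 2.8-fold lower number from compound 1 to compound 4 (0.44 log units; beyond the scatter), so the carbonyl carbon attached to the amide-type nitrogen accepts vinyl in place of methyl with a modest gain rather than a loss. Within the data shown here, this is the only single-place change in the set, as the earlier compounds differ from compound 1 in other ways. Nothing available explains the gain.

As far as these compounds go, whether ethyl, which lacks the double bond, would give a similar number on this carbonyl carbon stays open. The same is true of a longer chain such as propyl.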